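The source may report more compounds than this note shows. Statements on the series, on what has been measured and on what is new or still open speak of the compounds shown alone.

Measured so far:
compound 1, `CC(=O)NCc1cccc(Cn2nc(NS(=O)(=O)c3ccc(Cl)s3)c3ccccc32)c1`, 251 nM;
compound 2, `CC(=O)NCc1cccc(Cn2nc(NS(=O)(=O)c3ccc(Cl)s3)c3c(Cl)cccc32)c1`, 31.6 nM;
compound 3, `COc1cccc2c1c(NS(=O)(=O)c1ccc(Cl)c(Cl)c1)nn2Cc1cccc(CNC(=O)C(C)(C)O)c1`, 398 nM.

All three were run in a functional assay on CHO cells for antagonist activity at C-C chemokine receptor type 4 (Homo sapiens), read by GTPgammaS binding; a higher number here means a weaker inhibitor, a lower number a stronger inhibitor. Compound 2 and compound 1 differ by hydrogen in place of chloro on an aromatic carbon, and the step is a 7.9-fold higher number from compound 2 to compound 1 (0.90 log units; beyond the scatter). Compound 3 carries a different core; how the core of compound 3 and the core of compound 2 differ is not broken down here. Against compound 1 the value of compound 3 lies within the scatter, and against compound 2 it is clearly higher.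

Compound 4, `COc1cccc2c1c(NS(=O)(=O)c1cccc(Cl)c1)nn2Cc1cccc(CNC(=O)C(C)(C)O)c1`, is not yet measured. It differs from compound 3 by hydrogen in place of chloro on an aromatic carbon. This is the same kind of change as that from compound 2 to compound 1, but not the same: there the carbon sits in a ring that is part of a fused or bridged system of two rings, ortho to a fused ring and meta to a fused ring; here it sits ortho to a chloro group and para to a large group. Since the earlier step of a 7.9-fold higher number from compound 2 to compound 1 (0.90 log units; beyond the scatter) went toward a higher number on loss of chloro, a rise is also expected for compound 4, though a smaller one, estimated at a 2.5-fold higher number from compound 3 to compound 4 (0.40 log units; beyond the scatter) in this assay. Compound 4 is thus expected at about 1000 nM, between 350 nM and 3000 nM.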

Compound 4, half-maximal inhibitory concentration in the C-C chemokine receptor type 4 assay: 50.1 nM
Estimate against measurement, compound 4: 20-fold (1.30 log units) above, outside the stated range (below it).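

In the C-C chemokine receptor type 4 assay, hydrogen in place of chloro on the 3,4-dichlorophenyl group gives a 7.9-fold lower number from compound 3 to compound 4 (0.90 log units; beyond the scatter); in a physicochemical assay for acid dissociation, compound 3 gives 6.76 and compound 4 gives 7.06 and the same change gives a number 0.30 log units higher from compound 3 to compound 4 (within the scatter). Set beside the earlier step, this shows that the direction of a chloro-to-hydrogen change does not carry from one core to another in this series: the same change on two cores in the C-C chemokine receptor type 4 assay, a 7.9-fold higher number (0.90 log units; beyond the scatter) from compound 2 to compound 1 and a 7.9-fold lower number (0.90 log units; beyond the scatter) from compound 3 to compound 4, 63-fold (1.80 log units) apart, beyond the scatter of two such steps It does not show what sets the direction, since one chloro leaves a ring of the core and the other leaves the 3,4-dichlorophenyl group, the two pairs also differ elsewhere, and each direction rests on a single pair of compounds.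

Open, from the compounds shown here alone, is whether the reversal follows the place of the chloro or the rest of the molecule, which would need the same change made at one place on both cores. Also open, going by these compounds, is whether a fluoro or methyl group on that aromatic carbon would read like chloro or like hydrogen in the C-C chemokine receptor type 4 assay.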